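The source may hold more compounds than are shown below. What is called first, only, known or untested is meant among the compounds shown, and "the series" means these compounds.

Among the compounds with values here, in a functional assay on DU-145 cells (Homo sapiens) for antiproliferative activity, read by MTT assay, with a stated time of 24 h (on this read-out higher numbers stand for weaker inhibition and lower numbers for stronger inhibition), compound 1 `COc1ccc(-c2noc(C3CCNCC3)n2)cc1OC1CCCC1` gives 57 nM, the only value that is a true number. Compound 2 `COc1ccc(-c2noc(Cc3c[nH]c4ccccc34)n2)cc1OC1CCCC1` reads > 1000000 nM, which is a limit of the assay. Compound 3 `Fc1ccc(-c2nc(-c3ccccc3)no2)cc1` reads > 1000000 nM, likewise a limit. Compound 4 `COc1ccc(-c2noc(-c3ccc(Cl)cc3)n2)cc1OC1CCCC1` carries 4-chlorophenyl in place of piperidin-4-yl on an aromatic carbon. Within the data shown here, no measured step connects compound 1 to any other compound. A large step towards weaker inhibition in this assay is nevertheless expected, well beyond the scatter, resting on compound 2 and compound 3, both without piperidin-4-yl, and on (the limit of > 1000000 nM in this assay, at which 2 of the 3 values shown sit). The estimated change is a 3500-fold higher number from compound 1 to compound 4 (3.55 log units; beyond the scatter). For compound 4 the expected value is 200000 nM, with an estimated range of 2000 nM to 1000000 nM.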

Compound 4, half-maximal inhibitory concentration: 123000 nM
Compound 4: middle estimate off by 1.6-fold (0.21 log units), on the high side, within the range that was stated.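

In this assay, within the data shown here, 4-chlorophenyl in place of piperidin-4-yl gives a 2200-fold higher number from compound 1 to compound 4 (3.33 log units; beyond the scatter), the first step at this position that can be read as a number. All else in the core of compound 1 is kept, so this single change carries the whole loss. Compound 4 gives a true number rather than a limit, which sets it apart from the other weak compounds: the limit of > 1000000 nM in this assay, at which 2 of the 4 values shown sit.

Still open, on these data alone, is whether the ring nitrogen of piperidin-4-yl or its non-aromatic ring matters more. A cyclohexyl group or an open-chain amine at this position would separate the two.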